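Extending the amide of compound 1 toward a basic ring

A few compounds are considered here, and "the series" means these few. Any claim that something is new, unique, unknown or untested is made for them only; others in the source may bear on it.

Compound 1, `CNC(=O)c1cc(-c2ccc(NS(=O)(=O)c3cccc(Cl)c3Cl)cc2)nc2[nH]ncc12`, carries a methyl on its amide-type nitrogen. In an assay for inhibition of serine/threonine-protein kinase Sgk1 (Homo sapiens), with stated times of 30 min and 60 min, in the presence of a further agent that is not named here (a higher number here means a weaker inhibitor, a lower number a stronger inhibitor), compound 1 gives 4 nM. Among the measured compounds shown here, it is the only compound here with a plain number; compound 2, `CN1CC(NC(=O)c2cc(-c3ccc(NS(=O)(=O)c4cccc(Cl)c4Cl)cc3)nc3[nH]ncc23)C1`, reaches only a limit of the assay. In this assay compound 2 gives < 1 nM, a limit rather than a number. For the measured compounds named here, the one measured step, an at least 4.0-fold lower number from compound 1 to compound 2 (0.60 log units; beyond the scatter), shows that 1-methylazetidin-3-yl in place of methyl lowers the number, and the limit of < 1 nM in this assay, at which 1 of the 2 values shown sits, marks how far the assay could follow it.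

Compound 3, `CCN1CCC(CNC(=O)c2cc(-c3ccc(NS(=O)(=O)c4cccc(Cl)c4Cl)cc3)nc3[nH]ncc23)C1`, differs from compound 1 by 1-ethylpyrrolidin-3-yl in place of hydrogen on a saturated chain carbon bound to an amide-type nitrogen. This resembles the change from compound 1 to compound 2 in adding a saturated ring containing nitrogen at the amide, so a drop of similar size is expected. For compound 3 the estimate is a 2.7-fold lower number from compound 1 to compound 3 (0.43 log units; beyond the scatter). Compound 3 is expected to give 1.5 nM, with a range from 0.5 nM to 5 nM, and a fair chance that this assay again reports only a limit.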

Compound 3, half-maximal inhibitory concentration: < 1 nM
Compound 3: only a limit was reported (the forecaster's own chance of this, stated with the estimate: 35%); middle value at least 1.5-fold (0.17 log units) from the limit.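

Placing 1-ethylpyrrolidin-3-yl on a saturated chain carbon bound to an amide-type nitrogen gives an at least 4.0-fold lower number from compound 1 to compound 3 (0.60 log units; beyond the scatter), so the lower number is not confined to the 1-methylazetidin-3-yl group: a five-membered ring containing nitrogen, attached through a chain carbon, goes with it too. In this assay compound 3 gives < 1 nM, which is a limit of the assay and not a number. The step from compound 2 to compound 3 cannot be read, because both compounds stop at the same limit: the limit of < 1 nM in this assay, at which 2 of the 3 values shown sit.

Which of the two rings serves better therefore remains open. So does the part played by the ring nitrogen, which a cyclopentyl group, with carbon in its place, or a plain longer chain at the amide could help to settle.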